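A few compounds are considered here, and "the series" means these few. Any claim that something is new, unique, unknown or untested is made for them only; others in the source may bear on it.

In an assay on HEK293 cells for inhibition of Voltage-dependent T-type calcium channel subunit alpha-1H (Homo sapiens), read by patch clamp, using a membrane potential dye (a lower number here means a stronger inhibitor, a higher number a weaker inhibitor), compound 1 `COC(=O)[C@H](CO)NC(=O)N1CCC2(CC1)C(=O)N(c1cccc(F)c1)C2c1ccc(Cl)cc1` gives 3330 nM, while compound 2 `C[C@@H](NC(=O)N1CCC2(CC1)C(=O)N(c1cccc(F)c1)C2c1ccc(Cl)cc1)c1ccccc1` gives 351 nM, the lower of the two numbers; the step of a 9.5-fold lower number from compound 1 to compound 2 (0.98 log units; beyond the scatter) is the only one measured. Compound 3 `CC[C@H](NC(=O)N1CCC2(CC1)C(=O)N(c1cccc(F)c1)C2c1ccc(Cl)cc1)c1ccccc1` differs from compound 2 by 1-phenylpropyl in place of 1-phenylethyl on an amide-type nitrogen. For the measured compounds named here, no measured step concerns this lengthening of the group on the amide-type nitrogen, and the step from compound 1 to compound 2 swaps a quite different group, so it offers no direct guide. Compound 3 is therefore expected to stay close to compound 2, with a step of a 1.0-fold lower number from compound 2 to compound 3 (0.00 log units; within the scatter) and an estimated value of 350 nM in this assay, within 120 nM to 1000 nM.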

Compound 3, half-maximal inhibitory concentration: 224 nM
Beside the measured number, compound 3's estimate is 1.6-fold (0.19 log units) above it; the measured number falls inside the stated range.
By their numbers in this assay, from the lowest: compounds 3 and 2 (each within the scatter of the next); then compound 1.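

In this assay lengthening 1-phenylethyl to 1-phenylpropyl on the amide-type nitrogen gives a 1.6-fold lower number from compound 2 to compound 3 (0.20 log units; within the scatter) and so the two groups cannot be told apart at this position. Replacing 2-hydroxy-1-(methoxycarbonyl)ethyl with 1-phenylpropyl gives a 15-fold lower number from compound 1 to compound 3 (1.17 log units; beyond the scatter) and so shows that a second aryl-bearing group at this position also stands well clear of compound 1. No evidence is available that bears on either step.
From the compounds shown here alone, whether a longer chain such as 1-phenylbutyl would stay at this level remains open, as does the outcome of placing an amine on that chain.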